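A few compounds are considered here, and "the series" means these few. Any claim that something is new, unique, unknown or untested is made for them only; others in the source may bear on it.

Measured so far:
compound 1 `CC(C)C[C@@H]1NC(=O)[C@H](CC(C)C)NC(=O)[C@H](CC(C)C)NC(=O)[C@@H](Cc2c[nH]c3ccccc23)NC(=O)[C@H](CC(C)C)NC1=O` — 18%
compound 2 `CC(C)C[C@@H]1NC(=O)[C@H](Cc2ccccc2)NC(=O)[C@H](CC(C)C)NC(=O)[C@@H](C(C)C)NC(=O)[C@H](CCCCN)NC1=O` — 20%

In a functional assay on PL45 cells (Homo sapiens) for inhibition, tested at 5 uM (a lower number here means less inhibition, a higher number more inhibition at the concentration tested (going by the name of the read-out)), compound 1 gives 18%. Compound 2, which differs from it at several places of the shared core, gives 20% in this assay. Compound 1 stands at one of two numbers that lie within the usual scatter of each other, so neither compound can be called weaker or stronger than the other; both show only low inhibition at the concentration tested.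

Compound 3 `CC(C)C[C@@H]1NC(=O)[C@H](CC(C)C)NC(=O)[C@H](CC(C)C)NC(=O)[C@@H](Cc2ccc(O)cc2)NC(=O)[C@H](CC(C)C)NC1=O` is the next compound. It differs from compound 1 in one place: 4-hydroxyphenyl in place of 1H-indol-3-yl on a saturated chain carbon bound to a saturated ring carbon. Among the compounds with values here, no pair of measured compounds differing in one place is available, so the size of such a change in this assay has not been seen here. What the two measured compounds do show is that rather different side chains around the same core gave about the same low number. The step from compound 1 to compound 3 is therefore expected to be small, no change at the digits printed from compound 1 to compound 3 (within the scatter), with no change beyond the scatter in either direction.

For compound 3 the estimated inhibition is 18%, within a range of 5% to 35%.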

Compound 3, a percentage reported as inhibition, at one concentration (the size of the read-out at that concentration, not a potency): 46%
Compound 3: middle estimate off by 28 percentage points, on the low side; the measured number lies above the stated range.
By their numbers in this assay, from the lowest: compounds 1 and 2 (each within the scatter of the next); then compound 3.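

Swapping one side chain on the shared core can clearly move the inhibition: in this assay, 4-hydroxyphenyl in place of 1H-indol-3-yl on a saturated chain carbon bound to a saturated ring carbon gives a number 28 percentage points higher from compound 1 to compound 3 (beyond the scatter) with the rest of the molecule unchanged. Compound 1 and compound 2 differ at several places, so their pair could not show what any single group contributes, whereas this pair ties the difference to one place. Nothing available here explains why this exchange goes with more inhibition.

The pair also cannot say whether the gain comes from the hydroxyl group or from replacing the two-ring indole with a single ring, and a plain phenyl or a 4-methoxyphenyl at this same place would help separate those two possibilities. Also open, going by these compounds, is how a carboxylic acid or an amine at the end of this side chain would behave, and whether the same exchange would have a similar effect on the different side chains of compound 2.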